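The compounds below may be only part of what the source reports. "The series", "measured", "known", "first", "only" and "open" are said of these compounds alone.

Compound 1 `CC(C)COc1cccc(-c2ccc(C(=O)N(Cc3cccc(OCCCCCC(=O)O)c3)C(C)C)cc2)c1` — in an ADME assay on HEK293 cells (Homo sapiens) for cytotoxicity, read by CellTiter-Glo and resazurin assay, with a stated time of 72 h (a lower number here means that less compound is needed, a higher number that more compound is needed for the effect), compound 1 gives > 26000 nM, which is a limit of the assay and not a number.
Compound 2 `CC(C)N(Cc1cccc(OCCCCCC(=O)O)c1)C(=O)c1ccc(-c2ccoc2)cc1` — in this assay compound 2 gives > 26000 nM, again a limit of the assay.
Compound 3 `CC(C)N(Cc1cccc(OCCCCCC(=O)O)c1)C(=O)c1ccc(-c2ccco2)cc1` — in this assay compound 3 gives > 26000 nM, likewise a limit of the assay.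

Compound 3 therefore stands only at a limit, and the two other values shown stand at the same limit (the limit of > 26000 nM in this assay, at which 3 of the 3 values shown sit). The steps among the measured compounds cannot be read: a step that the two limits leave unreadable from compound 1 to compound 2, a step that the two limits leave unreadable from compound 1 to compound 3 and a step that the two limits leave unreadable from compound 2 to compound 3 are all left unreadable by the limits on both sides.

Compound 4 `CC(C)N(Cc1cccc(OCCCCCC(=O)O)c1)C(=O)c1ccc(-c2ccc3cc[nH]c3c2)cc1` is not yet measured. It differs from compound 3 in one place: 1H-indol-6-yl in place of furan-2-yl on an aromatic carbon. Within the data shown here, none of the measured steps gives a readable size that would bear on this change, so no direction can be drawn from them; what is known is only that every value so far sits at the limit (the limit of > 26000 nM in this assay, at which 3 of the 3 values shown sit).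

The expectation for compound 4 in this assay is accordingly a step that the limit leaves unreadable from compound 3 to compound 4 and an estimated value of 40000 nM, with a range from 15000 nM to 120000 nM.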

Compound 4, half-maximal effective concentration: > 26000 nM
Compound 4 was reported as a limit (the forecaster's own chance of this, stated with the estimate: 75%); the middle value is on the limit's open side.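

Among these compounds, compound 4 is also reported only as a limit of the assay, so no step between it and compound 1, compound 2 or compound 3 can be read: the limit of > 26000 nM in this assay, at which 4 of the 4 values shown sit. The compounds shown leave open whether exchanging these groups changes the effect in this assay at all.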